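The compounds below may be only part of what the source reports. "The series", "measured", "known", "first", "only" and "open" are said of these compounds alone.

Compounds measured so far:
compound 1 `O=C(c1c(O)ccc2cc(-c3cccc(O)c3)ccc12)N1CCOCC1`: 28%
compound 2 `O=C(c1c(O)ccc2cc(-c3cccc(O)c3)ccc12)N1CCCCC1`: 29%

Compound 1 gives the lowest of the two numbers in an in vitro assay on Sf9 cells for inhibition of 17-beta-hydroxysteroid dehydrogenase type 1 (Homo sapiens), tested at 100 nM; on this read-out lower numbers stand for a weaker effect and higher numbers for a stronger effect at the one concentration tested; compound 2 sits right beside it, a number 1 percentage points higher from compound 1 to compound 2 (within the scatter). Compound 3 `O=C(Nc1cccc(O)c1)c1c(O)ccc2cc(-c3cccc(O)c3)ccc12` differs from compound 1 in one place: (3-hydroxyphenyl)amino in place of morpholin-4-yl on a carbonyl carbon. Among the compounds with values here, the only measured step, swapping one six-membered non-aromatic ring for another, bears on this change only loosely, and it was small. No firm direction can be read from it. Compound 3 is therefore expected to land near compound 1, the estimated step being a number 7 percentage points higher from compound 1 to compound 3 (within the scatter). The estimate for compound 3 is 35%, with a wide range from 10% to 65%.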

Compound 3, a percentage reported as inhibition, at one concentration (the size of the read-out at that concentration, not a potency): 21%
Compound 3: middle estimate off by 14 percentage points, on the high side, and the stated range covers the measured number.
By their numbers in this assay, from the lowest: compounds 3, 1 and 2 (each within the scatter of the next).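

In this assay, the step to an aromatic (3-hydroxyphenyl)amino group on the carbonyl carbon, which carries hydrogen-bond donors that morpholin-4-yl and piperidin-1-yl lack, is a number 7 percentage points lower from compound 1 to compound 3 (within the scatter) and a number 8 percentage points lower from compound 2 to compound 3 (within the scatter). So a ring of a quite different kind can stand at this position while the read-out stays within the scatter. No supporting data bear on this result.

Going by these compounds, whether a plain phenylamino group without the hydroxyl, or a small open-chain dimethylamino group, would read differently stays open. So does whether any group on this carbonyl carbon can move the number beyond the scatter.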